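The compounds below may be only part of what the source reports. "The series", "measured", "known", "first", "only" and "open" are said of these compounds alone.

Measured so far in a functional assay on HCT-116 cells (Homo sapiens), read by MTT assay, with a stated time of 72 h; on this read-out lower numbers stand for stronger inhibition and higher numbers for weaker inhibition:
Compound 1 `Cc1ncnc2c1c(I)cn2[C@@H]1O[C@H](CO)[C@@H](O)[C@H]1O` gives 7570 nM.
Compound 3 `C#Cc1cn([C@@H]2O[C@H](CO)[C@@H](O)[C@H]2O)c2ncnc(OC)c12` gives 5140 nM.
Compound 2 `CNc1ncnc2c1c(I)cn2[C@@H]1O[C@H](CO)[C@@H](O)[C@H]1O` reaches only a limit of the assay, > 100000 nM.

Compound 3 holds the lowest of the two numbers in this assay; its nearest neighbour is compound 1, whose higher number lies within the scatter. Compound 4 `COc1ncnc2c1c(I)cn2[C@@H]1O[C@H](CO)[C@@H](O)[C@H]1O` differs from compound 3 by iodo in place of ethynyl on an aromatic carbon. Going by the values given here, the one measured step, an at least 13-fold higher number from compound 1 to compound 2 (1.12 log units; beyond the scatter), concerns another group at another place and so does not bear on this change; beyond it there is only (the limit of > 100000 nM in this assay, at which 1 of the 3 values shown sits). Among the compounds with values here, with no step covering the exchange of ethynyl for iodo, compound 4 is expected to stay close to compound 3, an estimated step of a 1.6-fold higher number from compound 3 to compound 4 (0.19 log units; within the scatter). Compound 4 is estimated at 8000 nM, with a range from 2500 nM to 25000 nM.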

Compound 4, half-maximal inhibitory concentration: > 20000 nM
Compound 4: a limit, no number; the forecaster's own chance of this, stated with the estimate: 10%; at least 2.5-fold (0.39 log units) between middle value and limit.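

In this assay, the group on this aromatic carbon of the five-membered ring proves to matter: with methoxy kept on the core, iodo in place of ethynyl brings an at least 3.8-fold higher number from compound 3 to compound 4 (0.59 log units; beyond the scatter). With iodo kept, methoxy in place of methyl on the other aromatic carbon brings an at least 2.6-fold higher number from compound 1 to compound 4 (0.42 log units; beyond the scatter), so that exchange also counts. The step between the methylamino and methoxy compounds cannot be read, as both values are limits. Still open, on these data alone, is how far the true value of compound 4 lies past its limit, and whether a longer alkyne chain or an aminomethyl group on this carbon would fare as ethynyl does.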